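The source may hold more compounds than are shown below. What is called first, only, known or untested is meant among the compounds shown, and "the series" means these compounds.

Measured so far in a functional assay for inhibition, with Homo sapiens as the target; on this read-out lower numbers stand for stronger inhibition and higher numbers for weaker inhibition:
Compound 1, `CCc1nnc(O)n2c(C(C)CC)nc(C)c12`, gives 45000 nM.
Compound 2, `CCc1nnc(O)n2c(C)nc(C)c12`, gives only a limit of the assay, not a number: > 48000 nM.
Compound 3, `CCc1nc(C)c2cnnc(O)n12`, likewise gives only a limit, not a number: > 48000 nM.

Compound 3 thus stands at the ceiling of what this assay can report, and it is not alone there, as the limit of > 48000 nM in this assay, at which 2 of the 3 values shown sit, shows. For the measured compounds named here, only one full step between measured compounds exists, an at least 1.0-fold higher number from compound 1 to compound 2 (0.02 log units; that floor lies within the scatter), and it lies within the scatter: exchanging sec-butyl for methyl on an aromatic carbon produced no visible shift.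

Compound 4, `CCc1nnc(O)n2c(CC)nc(C)c12`, differs from compound 3 by ethyl in place of hydrogen on an aromatic carbon. Going by the values given here, no measured step covers this exact exchange. The nearest comparison is the step from compound 1 to compound 2, where a change of the group on that aromatic carbon did nothing beyond the scatter, and the two weakest results share the same limit. The expected step is a number no higher from compound 3 to compound 4 (the limit leaves the size open), within the scatter, with a fair chance that only a limit is returned again. Compound 4 is estimated at 48000 nM, with a range from 20000 nM to 150000 nM.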

Compound 4, half-maximal inhibitory concentration: 24000 nM
For compound 4 the middle estimate is 2.0-fold (0.30 log units) above the measured one; the measured number falls inside the stated range.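

In this assay, ethyl on this aromatic carbon gives a number rather than a limit, which neither hydrogen in compound 3 nor methyl in compound 2 did: the limit of > 48000 nM in this assay, at which 2 of the 4 values shown sit.

That shift off the limit is still small, since the steps, an at least 2.0-fold lower number from compound 3 to compound 4 (0.30 log units; that floor lies within the scatter) and an at least 2.0-fold lower number from compound 2 to compound 4 (0.30 log units; that floor lies within the scatter), have floors that stay inside the usual scatter. Ethyl and sec-butyl cannot be told apart at this position, with a 1.9-fold lower number from compound 1 to compound 4 (0.27 log units; within the scatter), so going from the two-carbon ethyl to sec-butyl brings no visible gain.

As far as these compounds go, whether a phenyl ring, an amine or a chain longer than sec-butyl on this aromatic carbon could move the number beyond the scatter remains open. The compounds shown also leave open how far any such gain would go.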